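From 3,5-dimethylphenyl to 2,3-dimethylphenyl on the sulfonamide nitrogen

The source may report more compounds than this note shows. Statements on the series, on what has been measured and on what is new or still open speak of the compounds shown alone.

In a functional assay on M21 cells (Homo sapiens) for antiproliferative activity, read by sulforhodamine B assay, with a stated time of 48 h (a lower number here means a stronger inhibitor, a higher number a weaker inhibitor), compound 2 (`Cc1cc(C)cc(NS(=O)(=O)c2ccc(N3CCNC3=O)cc2)c1`) gives 63 nM and compound 1 (`Cc1cccc(NS(=O)(=O)c2ccc(N3CCNC3=O)cc2)c1`) gives 69 nM so the two stand level within the scatter. Compound 3 (`Cc1cccc(NS(=O)(=O)c2ccc(N3CCNC3=O)cc2)c1C`) has 2,3-dimethylphenyl in place of 3,5-dimethylphenyl on a sulfonamide nitrogen. For the measured compounds named here, the only measured step that bears on this is a 1.1-fold lower number from compound 1 to compound 2 (0.04 log units; within the scatter) and it lies within the scatter, though it adds a methyl rather than rearranging one. Going by the values given here, no measured compound carries 2,3-dimethylphenyl, so the expected step is small, a 1.3-fold higher number from compound 2 to compound 3 (0.13 log units; within the scatter) and no shift clearly beyond the scatter is expected. Compound 3 is estimated at 85 nM (expected range 30 nM to 220 nM).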

Compound 3, half-maximal inhibitory concentration: 110 nM
Beside the measured number, compound 3's estimate is 1.3-fold (0.11 log units) below it; low and high end bracket the measured number.
By their numbers in this assay, from the lowest: compounds 2, 1 and 3 (each within the scatter of the next).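

In this assay, exchanging 3,5-dimethylphenyl for 2,3-dimethylphenyl on the sulfonamide nitrogen gives a 1.7-fold higher number from compound 2 to compound 3 (0.24 log units; within the scatter), so rearranging the methyl groups, and not only adding one, leaves the number within the scatter. The second methyl addition gives a 1.6-fold higher number from compound 1 to compound 3 (0.20 log units; within the scatter), which also stays within the scatter, so neither dimethylphenyl group separates clearly from compound 1. No evidence on hand bears on these small differences. Still open, from the compounds shown here alone, is whether an amine or a carboxylic acid on this phenyl ring, or a longer chain in place of methyl, would move the number beyond the scatter.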